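A Hydroxy Group Replaces Acetyl on the Pyrimidine Ring

A few compounds are considered here, and "the series" means these few. Any claim that something is new, unique, unknown or untested is made for them only; others in the source may bear on it.

Of the compounds shown here, three have been tested in a functional assay on cells for agonist activity at Glucose-dependent insulinotropic receptor (Homo sapiens), read by a luciferase reporter, with a stated time of 4 h; on this read-out higher numbers stand for larger maximal responses and lower numbers for smaller maximal responses. Compound 1 `CC(C)(C)OC(=O)N1CCC(c2coc3c(N4CCCc5cc(S(C)(=O)=O)ccc54)ncnc23)CC1` gives 1% in this assay. Compound 2 `CC(=O)c1cnc(N2CCC(c3coc4c(N5CCc6cc(S(C)(=O)=O)ccc65)ncnc34)CC2)nc1` gives 12%, and compound 3 `CC(C)(C)OC(=O)N1CCC(c2noc3c(Nc4ccc(S(C)(=O)=O)cc4F)ncnc23)CC1` gives 137%. Among these three numbers compound 2 stands second highest: its nearest neighbour is compound 1, lower by a gap beyond the usual scatter, and its furthest is compound 3, higher by a gap far beyond the scatter. No two of the measured compounds differ in only one place, so no single step can be read from them, and the wide gap between compound 2 and compound 3 comes with several structural changes at once.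

Compound 4 `CS(=O)(=O)c1ccc2c(c1)CCN2c1ncnc2c(C3CCN(c4ncc(O)cn4)CC3)coc12` has not yet been measured. It differs from compound 2 in one place: hydroxy in place of acetyl on an aromatic carbon Read one bond further out, the change is from 5-acetylpyrimidin-2-yl to 5-hydroxypyrimidin-2-yl, on an aromatic carbon of a six-membered aromatic ring with 2 nitrogen, two atoms from the ring nitrogen. For the measured compounds named here, nothing measured so far shows what such a change does at this position, so only a small step, within or close to the scatter and with no clear direction, is expected; the estimated step is a number 2 percentage points lower from compound 2 to compound 4 (within the scatter). Compound 4 is therefore expected to reach 10%, with a range from 0% to 35%.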

Compound 4, largest response reached (Emax), in percent of the reference or control that the assay uses: 145%
Estimate against measurement, compound 4: 135 percentage points below; the whole stated range lies below it.
By their numbers in this assay, from the lowest: compound 1; then compound 2; then compounds 3 and 4 (each within the scatter of the next).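

For the compounds shown here, this is the first comparison in the set in which only one place changes, and it shows that this carbon of the pyrimidine ring, para to a large group, strongly affects the maximal response. In this assay, replacing 5-acetylpyrimidin-2-yl with 5-hydroxypyrimidin-2-yl gives a number 133 percentage points higher from compound 2 to compound 4 (beyond the scatter), so a single small substitution here can separate a weak maximal response from a high one. The swap exchanges a larger group with a double bond and no hydrogen-bond donor for a smaller group that has one, but no measurement shown here tells which of these differences accounts for the step.

From the compounds shown here alone, with only these two groups at this carbon, it remains open whether the rise comes from the presence of hydroxy or from the absence of acetyl, and an amine, a methoxy group or a carboxylic acid at the same carbon would help to separate the two readings. Steps involving compound 1 or compound 3 cannot be read, since those compounds differ from the others in more than one place, so whether this change would have the same effect on another core also stays open.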